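A few compounds are considered here, and "the series" means these few. Any claim that something is new, unique, unknown or untested is made for them only; others in the source may bear on it.

The three measured compounds share a core, seen in compound 1 `Cc1cccc(Cn2cc(COc3ccc4c(=O)ccoc4c3)nn2)c1`, compound 2 `O=c1ccoc2cc(OCc3cn(Cc4cccc(Cl)c4)nn3)ccc12` and compound 3 `O=c1ccoc2cc(OCc3cn(Cc4ccccc4F)nn3)ccc12`, and differ only in the group on the saturated chain carbon bound to an aromatic nitrogen. In a functional assay on A549 cells (Homo sapiens) for cytotoxicity, read by MTT assay, with a stated time of 48 h (a lower number here means a stronger inhibitor, a higher number a weaker inhibitor), compound 1 gives 20300 nM, compound 2 gives 13700 nM and compound 3 gives 10800 nM. Compound 2 stands second highest of the three numbers, with a 1.5-fold lower number from compound 1 to compound 2 (0.17 log units; within the scatter) on one side and a 1.3-fold lower number from compound 2 to compound 3 (0.10 log units; within the scatter) on the other; the remaining step, a 1.9-fold lower number from compound 1 to compound 3 (0.27 log units; within the scatter), is also within the scatter. Compound 4 `N#Cc1ccc(Cn2cc(COc3ccc4c(=O)ccoc4c3)nn2)cc1` has not yet been measured. Its change from compound 2 is 4-cyanophenyl in place of 3-chlorophenyl on a saturated chain carbon bound to an aromatic nitrogen. All three measured steps swap the group at this same place, and none of them moved the number beyond the scatter, so a step of similar size and no clear direction is expected here: a 1.1-fold lower number from compound 2 to compound 4 (0.06 log units; within the scatter). Compound 4 is therefore estimated at 12000 nM, with a range from 5000 nM to 30000 nM.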

Compound 4, half-maximal inhibitory concentration: > 100000 nM
Compound 4 gave a limit, no number (the forecaster's own chance of this, stated with the estimate: 5%); at least 8.3-fold (0.92 log units) between middle value and limit.
By their numbers in this assay, from the lowest: compounds 3, 2 and 1 (each within the scatter of the next). At a limit, above all of these: compound 4.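

In this assay compound 4 gave no number, only a limit of the assay: the limit of > 100000 nM in this assay, at which 1 of the 4 values shown sits. Until now this position looked tolerant, since swapping among 3-methylphenyl, 3-chlorophenyl and 2-fluorophenyl stayed within the scatter, but 4-cyanophenyl gives an at least 7.2-fold higher number from compound 2 to compound 4 (0.86 log units; beyond the scatter) and an at least 9.2-fold higher number from compound 3 to compound 4 (0.96 log units; beyond the scatter) and an at least 4.9-fold higher number from compound 1 to compound 4 (0.69 log units; beyond the scatter). All three steps lie beyond the scatter and point the same way, so the group on this saturated chain carbon can decide whether the cytotoxicity is seen at all within the range of the assay.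

On these data alone, whether this loss goes with the nitrile itself or with where it sits on the ring stays open, and a 3-cyanophenyl or a 4-chlorophenyl group would separate the two. As far as these compounds go, the full size of the step also stays open, since a limit sets only its minimum.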